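The source may hold more compounds than are shown below. What is called first, only, known or untested is meant among the compounds shown, and "the series" means these compounds.

The three measured compounds, with their results in a functional assay on RXF 393 cells (Homo sapiens) for inhibition, read by sulforhodamine B assay, with a stated time of 48 h; on this read-out higher numbers stand for weaker inhibition of growth and lower numbers for stronger inhibition of growth:

compound 1 `Nc1cc(N)c2nc(-c3ccccc3)c(NCc3ccc(Cl)c(Cl)c3)nc2c1`: 3090 nM
compound 2 `COc1ccc(CNc2nc3cc(N)cc(N)c3nc2-c2ccccc2)cc1OC`: 19100 nM
compound 3 `Nc1cc(N)c2nc(-c3ccccc3)c(NCc3ccc(F)cc3)nc2c1`: 12300 nM

All three share one core and differ only in the aromatic group carried on the saturated chain carbon bound to the ring nitrogen. Compound 3 gives the second highest number of the three. Its nearest neighbour is compound 2, and the gap between them, a 1.6-fold lower number from compound 2 to compound 3 (0.19 log units; within the scatter), is within the usual scatter. Compound 1 lies furthest away: a 4.0-fold higher number from compound 1 to compound 3 (0.60 log units; beyond the scatter), a modest step beyond the scatter.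

Compound 4 `COc1ccc(CNc2nc3cc(N)cc(N)c3nc2-c2ccccc2)cc1` has not yet been tested. It differs from compound 3 in one place: methoxy in place of fluoro on an aromatic carbon.

For the measured compounds named here, the step that bears most directly on this change is the one from compound 2 to compound 3, which swaps a methoxy-bearing ring for the fluoro-bearing one and stays within the scatter. The steps from compound 1 to compound 2 and from compound 1 to compound 3 both start from the chloro-bearing ring, so they speak to this change only indirectly. On that basis no step beyond the scatter is expected in this assay when fluoro gives way to methoxy. Compound 4 is therefore estimated at 15000 nM, within a range from 6000 nM to 40000 nM, which means an expected step of a 1.2-fold higher number from compound 3 to compound 4 (0.09 log units; within the scatter).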

Compound 4, concentration for 50% growth inhibition: 5370 nM
Beside the measured number, compound 4's estimate is 2.8-fold (0.45 log units) above it; measured number outside the range, below it.
By their numbers in this assay, from the lowest: compounds 1 and 4 (each within the scatter of the next); then compounds 3 and 2 (each within the scatter of the next).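

In this assay the swap of fluoro for methoxy on this aromatic carbon, para to a large group, is a real change: it gives a 2.3-fold lower number from compound 3 to compound 4 (0.36 log units; beyond the scatter) and is a modest step beyond the scatter. The earlier compounds shown here could not show this, since the only methoxy-bearing ring among them also carried a second methoxy, and that second group counts as well: replacing it with hydrogen gives a 3.6-fold lower number from compound 2 to compound 4 (0.55 log units; beyond the scatter) and is likewise beyond the scatter. The single methoxy also brings this series within the scatter of the 3,4-dichlorophenyl compound, with a 1.7-fold higher number from compound 1 to compound 4 (0.24 log units; within the scatter) as the listed step, something neither of the other two rings achieved, though no available measurement explains any of these steps.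

The compounds shown leave open whether the gain at this place follows the oxygen of the methoxy or would also appear with a hydroxyl, a methyl or an amine on the same aromatic carbon. They also leave open how an ethoxy group there, or a longer chain carrying the 4-methoxyphenyl ring, would read out in this assay on the same shared core.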